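A few compounds are considered here, and "the series" means these few. Any claim that something is new, unique, unknown or untested is made for them only; others in the source may bear on it.

Compound 1 `COc1ccc(OCC(=O)N2CCN(c3ccc(C(F)(F)F)cc3[C@@H](N)CC(C)C)CC2)cc1` has the second highest number of the three in an assay on HEK293 cells for displacement of a labelled ligand from Melanocortin receptor 4 (Homo sapiens); on this read-out higher numbers stand for weaker inhibition and lower numbers for stronger inhibition: compound 1 gives 3800 nM, compound 3 `CC(C)C[C@H](N)c1cc(C(F)(F)F)ccc1N1CCN(C(=O)CCC2CCCCC2)CC1` gives 5700 nM, and compound 2 `CC(C)C[C@H](N)c1cc(C(F)(F)F)ccc1N1CCN(C(=O)C(C)Cc2ccc(Cl)cc2O)CC1` gives 36 nM. The step of a 1.5-fold higher number from compound 1 to compound 3 (0.18 log units; within the scatter) stays within the scatter, whereas a 110-fold lower number from compound 1 to compound 2 (2.02 log units; beyond the scatter) and a 160-fold higher number from compound 2 to compound 3 (2.20 log units; beyond the scatter) are large. Compound 4 `CC(C)C[C@H](N)c1cc(C(F)(F)F)ccc1N1CCN(C(=O)CNc2ccccc2)CC1` differs from compound 1 by anilino in place of 4-methoxyphenoxy on a saturated chain carbon bound to a carbonyl carbon. Among the measured compounds shown here, only the step from compound 1 to compound 3 alters the same place, and it barely moved the number; the large step to compound 2 rests on a different group and says little here. A small step, if any, is therefore expected. Compound 4 is expected at about 2500 nM, with a likely range from 700 nM to 9000 nM. That estimate means a step of a 1.5-fold lower number from compound 1 to compound 4 (0.18 log units; within the scatter).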

Compound 4, inhibition constant: 3600 nM
Compound 4: middle estimate off by 1.4-fold (0.16 log units), on the low side; the measured number falls inside the stated range.
By their numbers in this assay, from the lowest: compound 2; then compounds 4, 1 and 3 (each within the scatter of the next).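

Changing 4-methoxyphenoxy to anilino adds a hydrogen-bond donor on this saturated chain carbon, yet this assay shows a 1.1-fold lower number from compound 1 to compound 4 (0.02 log units; within the scatter) and a 1.6-fold lower number from compound 3 to compound 4 (0.20 log units; within the scatter) so both steps stay within the scatter. Thus anilino, 4-methoxyphenoxy and cyclohexylmethyl give comparable numbers here, while a 100-fold higher number from compound 2 to compound 4 (2.00 log units; beyond the scatter) leaves compound 4 far from compound 2. No measured evidence explains this flat response.

On these data alone, whether an amine or a carboxylic acid at this carbon would move the number remains open. So does which part of 1-(4-chloro-2-hydroxybenzyl)ethyl accounts for the large step.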